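The compounds below may be only part of what the source reports. "The series", "measured", "known", "first", "only" and "open" are said of these compounds alone.

Compound 2 `CCCCc1ccc2[nH]c(-c3ccc(OC)cc3)c(/C=N/O)c2c1` stands second highest of the three numbers in a functional assay on MDA-MB-231 cells (Homo sapiens) for antiproliferative activity, with a stated time of 4 days (on this read-out lower numbers stand for stronger inhibition and higher numbers for weaker inhibition), where compound 2 gives 40 nM. Compound 1 `CCCCc1ccc2[nH]c(-c3ccc(C(F)(F)F)cc3)c(C=O)c2c1` gives 33 nM in this assay, and compound 3 `CCCCc1ccc2[nH]c(-c3ccc(OC)cc3)c(/C=N/NC(=O)c3ccc(OC)cc3)c2c1` gives 61 nM; both of these lie within the scatter of the number for compound 2. The change from compound 2 to compound 4 `CCCCc1ccc2[nH]c(-c3ccc(OC)cc3)c(/C=N/NC(=O)c3ccncc3)c2c1` is ((pyridin-4-yl)carbonyl)amino in place of hydroxy on a double-bonded nitrogen. For the measured compounds named here, one measured step bears directly on it: a 1.5-fold higher number from compound 2 to compound 3 (0.18 log units; within the scatter), in which a ((4-methoxyphenyl)carbonyl)amino group took the place of the same hydroxy on the same double-bonded nitrogen. Going by the values given here, compound 4 carries a ((pyridin-4-yl)carbonyl)amino group at that place instead, and that earlier step is the closest precedent available, one that stayed within the scatter. Resting on this single comparison, the account expects compound 4 to show no step beyond the scatter in this assay, the expected step being a 1.5-fold higher number from compound 2 to compound 4 (0.18 log units; within the scatter). For compound 4 the estimated value is 60 nM, with a range from 30 nM to 130 nM.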

Compound 4, half-maximal inhibitory concentration: 29 nM
The estimate for compound 4 lay 2.1-fold (0.32 log units) above the measured number, and the stated range ends above it.
By their numbers in this assay, from the lowest: compounds 4, 1, 2 and 3 (each within the scatter of the next, the first and the last beyond it).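

With a 1.4-fold lower number from compound 2 to compound 4 (0.14 log units; within the scatter) in this assay, a second ((aryl)carbonyl)amino group on the double-bonded nitrogen stays within the scatter of the hydroxy, so this place accepts the much larger group in two different forms. For the compounds shown here, what the earlier compounds could not show is that the ring on the carbonyl carbon matters: a 2.1-fold lower number from compound 3 to compound 4 (0.32 log units; beyond the scatter) is a modest step, but it is the only single-place step here that lies beyond the scatter. Nothing available explains this difference between pyridin-4-yl and 4-methoxyphenyl.

On these data alone, it remains open whether a plain phenyl on the carbonyl carbon would stand with compound 3 or with compound 4, and so whether the ring nitrogen or the loss of the methoxy carries the step. As far as these compounds go, the effect of pyridin-3-yl, or of an amine or a carboxylic acid on that ring, is also open.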